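A phenyl group takes the place of cyclohexylmethyl

The source may hold more compounds than are shown below. What is called first, only, known or untested is meant among the compounds shown, and "the series" means these compounds.

In a functional assay on HeLa cells (Homo sapiens) for antiproliferative activity, read by sulforhodamine B assay (a higher number here means a weaker inhibitor of growth, a lower number a stronger inhibitor of growth), compound 1 `O[C@H]1CO[C@H](COCc2ccccc2)[C@@H](OCc2ccccc2)[C@@H]1OCc1ccccc1` gives > 50000 nM as a limit of the assay and not as a number. Among the compounds with values here, compound 2 `O[C@@H]1[C@@H](OCc2ccccc2)[C@H](OCc2ccccc2)[C@@H](COCc2ccccc2)O[C@H]1CC1CCCCC1` gives 9500 nM as the only exact number so far. Within the data shown here, the one measured change is an at least 5.2-fold lower number from compound 1 to compound 2 (0.72 log units; beyond the scatter) and it comes with cyclohexylmethyl in place of hydrogen on a saturated ring carbon. Compound 3 `O[C@@H]1[C@@H](OCc2ccccc2)[C@H](OCc2ccccc2)[C@@H](COCc2ccccc2)O[C@H]1c1ccccc1` exchanges that same group, and the difference phenyl in place of cyclohexylmethyl on a saturated ring carbon amounts to phenyl in place of cyclohexylmethyl on a saturated ring carbon. Among the measured compounds shown here, no measured step swaps one such group for another, so the earlier step offers only a loose guide. Compound 2 at 9500 nM and compound 3 both carry a six-membered ring on that saturated ring carbon, so only a small step is expected, perhaps toward a higher number, and none clearly beyond the scatter. The expected change is a 1.3-fold higher number from compound 2 to compound 3 (0.10 log units; within the scatter) in this estimate. In this assay the estimated value for compound 3 is 12000 nM with an expected range from 4000 nM to 40000 nM overall.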

Compound 3, concentration for 50% growth inhibition: > 50000 nM
Compound 3 was reported as a limit; the forecaster's own chance of this, stated with the estimate: 15%; middle value at least 4.1-fold (0.61 log units) from the limit.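

In this assay, this position, on the saturated ring carbon next to the ring oxygen, proves sensitive to which carbon ring it carries: with phenyl in place of cyclohexylmethyl, the result is an at least 5.2-fold higher number from compound 2 to compound 3 (0.72 log units; beyond the scatter). The earlier step showed only that cyclohexylmethyl gave a lower number than hydrogen, whereas this one shows that a six-membered carbon ring at this position is not enough to keep that number, and compound 3 gives > 50000 nM, which is a limit of the assay and not a number. The step between compound 1 and compound 3 cannot be read, and compound 2 remains the only compound here with an exact value: the limit of > 50000 nM in this assay, at which 2 of the 3 values shown sit.

The change replaces a non-aromatic ring with an aromatic one and removes the methylene link in the same step, so the compounds shown cannot tell which of the two goes with the higher number. Benzyl, which keeps that link on an aromatic ring, and cyclohexyl, which drops it from a non-aromatic ring, would separate the two, while an amine or a longer alkyl chain at this position remains open as well.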